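Half-life after intravenous dosing: defined versus undefined stereocentre

The source may hold more compounds than are shown below. What is called first, only, known or untested is meant among the compounds shown, and "the series" means these compounds.

Two compounds of the series have been run in an in vivo ADME assay on the whole organism (strain Sprague-Dawley) for metabolic stability, with Rattus norvegicus as the target, at a dose of 5 mg/kg by the intravenous route; a lower number here means that the compound disappears faster, a higher number that the compound lasts longer. Compound 1 `Cc1cccc(C)c1CN[C@]1(CCC(C)(C)C)C(=O)C(C2=NS(=O)(=O)c3cc(NS(C)(=O)=O)ccc3N2)=C(O)c2ccccc21` gives 3.1 h in this assay, the higher of the two numbers recorded. Compound 2 `CC(C)CC[C@@]1(NCc2ccccc2)C(=O)C(C2=NS(=O)(=O)c3cc(NS(C)(=O)=O)ccc3N2)=C(O)c2ccccc21` gives 1.7 h in this assay; the gap between compound 1 and compound 2 lies within the scatter, so the two read as alike. For the measured compounds named here, no step between measured compounds that differ in one place is available for this assay.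

Compound 3 `Cc1cccc(C)c1CNC1(CCC(C)(C)C)C(=O)C(C2=NS(=O)(=O)c3cc(NS(C)(=O)=O)ccc3N2)=C(O)c2ccccc21` is the next member to be tested. Compared with compound 1 the change is the two compounds have the same atoms and bonds; at least one stereo element is drawn with a configuration in one of them and without one in the other: 1 of 1 stereo elements differ; a stereocentre at a saturated ring carbon is drawn S in compound 1 and without a configuration in compound 3. Nothing in the two numbers recorded so far points to a difference of this kind moving the half-life beyond the scatter. The step from compound 1 to compound 3 is therefore expected to be a 1.0-fold lower number from compound 1 to compound 3 (0.01 log units; within the scatter), that is, no step beyond the scatter. Compound 3 is accordingly expected to give 3 h in this assay, with a range of 1.6 h to 5 h.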

Compound 3, half-life: 5 h
Estimate against measurement, compound 3: 1.7-fold (0.22 log units) below; the range from low to high includes it.
By their numbers in this assay, from the lowest: compounds 2, 1 and 3 (each within the scatter of the next, the first and the last beyond it).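

For the compounds shown here, this pair gives the first direct reading on the stereocentre at the saturated ring carbon, with all atoms and bonds held constant: in this assay the result is a 1.6-fold higher number from compound 1 to compound 3 (0.21 log units; within the scatter), so compound 1 and compound 3 read as alike. At this position, removing the drawn S configuration therefore produces no step beyond the scatter. The pair isolates one structural point only: the fact that one of compounds 1 and 3 is drawn with a defined configuration and the other without, at the place where they differ

A drawing without a configuration does not establish what compound 3 contains at this carbon, and a compound drawn R there with otherwise the same structure as compound 1 would be needed to compare the two configurations directly. As far as these compounds go, whether an amine or a carboxylic acid on the shared core would carry the half-life beyond the scatter also remains open.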